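A few compounds are considered here, and "the series" means these few. Any claim that something is new, unique, unknown or untested is made for them only; others in the source may bear on it.

Measured compounds:
compound 1, `CC(C)(C)C(=O)N1Cc2c(NC(=O)c3ccncc3)n[nH]c2C1(C)C`, 205000 nM
compound 2, `CC(C)CC(=O)Nc1n[nH]c2c1CN(C(=O)C1CCN(C3CC3)CC1)C2(C)C`, > 225000 nM

Within the data shown here, in a physicochemical assay for solubility, at pH 7 (a higher number here means a more soluble compound, a lower number a less soluble compound), compound 1 gives 205000 nM, the only number in the set. Compound 2 gives > 225000 nM, which is a limit of this assay and not a number. Among the measured compounds shown here, the single piece of evidence on the values is the limit of > 225000 nM in this assay, at which 1 of the 2 values shown sits. For the measured compounds named here, compound 1 therefore stands as the one compound placed by a number; compound 2 cannot be ordered against it, and no step between measured compounds is available to calibrate a change.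

Compound 3, `CC(C)(C)C(=O)N1Cc2c(NC(=O)c3cccnc3)n[nH]c2C1(C)C`, is still to be measured in this assay. It differs from compound 1 in one place: pyridin-3-yl in place of pyridin-4-yl on a carbonyl carbon. The two have the same atoms, joined differently, so the change is a rearrangement within the pyridinyl group rather than a gain or loss of atoms.

Going by the values given here, with no measured step to lean on, the step of a 1.1-fold lower number from compound 1 to compound 3 (0.06 log units; within the scatter) is expected to stay within the usual scatter, with no direction claimed. Compound 3 is estimated at 180000 nM, between 80000 nM and 400000 nM.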

Compound 3, solubility: 207000 nM
Compound 3: middle estimate off by 1.2-fold (0.06 log units), on the low side; the range from low to high includes it.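

In this assay, among these compounds, pyridin-3-yl in place of pyridin-4-yl on a carbonyl carbon gives a 1.0-fold higher number from compound 1 to compound 3 (0.00 log units; within the scatter) and this is the first step available, so the position now has one calibrated change where the earlier compounds offered none. At this place, on a carbonyl carbon whose other neighbour is an amide-type nitrogen, the rearrangement within the pyridinyl group leaves compound 1 and compound 3 indistinguishable in this read-out, although this single pair supports no wider pattern. No measured property in the data bears on this step.

Among the compounds shown here, whether the same place tolerates a pyridin-2-yl group, a plain phenyl ring, a carboxylic acid or a saturated amine such as piperidine stays open, as every group at this place so far is a pyridinyl isomer. For the compounds shown here, compound 2 gives > 225000 nM as a limit of the assay and not a number, and it differs from compound 1 in more than one place, so it provides no step for the series.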